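A few compounds are considered here, and "the series" means these few. Any claim that something is new, unique, unknown or untested is made for them only; others in the source may bear on it.

Two compounds have been measured in a functional assay on MCF7 cells (Homo sapiens) for antiproliferative activity, read by MTT assay, with a stated time of 48 h, in the presence of a further agent that is not named here; a lower number here means a stronger inhibitor of growth, a higher number a weaker inhibitor of growth:

Compound 1 `COc1ccc(-c2nn(-c3ccccc3)cc2C(=O)NOCc2ccccc2F)cc1` gives 6000 nM.
Compound 2 `O=C(NOCc1ccccc1)c1cn(-c2ccccc2)nc1-c1ccc(Cl)cc1` gives 10800 nM.

In this assay the number for compound 2 and the number for compound 1 lie within the usual scatter of each other, so the two cannot be told apart on these data. Compound 1 differs from compound 2 in more than one place, so no single change between them can be read off.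

The next compound is compound 3 `O=C(NOCc1ccccc1F)c1cn(-c2ccccc2)nc1-c1ccc(Cl)cc1`. It differs from compound 2 in one place only: fluoro in place of hydrogen on an aromatic carbon. The benzyloxy group of compound 2 becomes a (2-fluorobenzyl)oxy group, the same group that compound 1 carries. For the measured compounds named here, nothing in the measured pair isolates this change, so there is no measured step to lean on.

A change of one fluorine for a hydrogen, with no ring, donor or acceptor added, would usually be expected to give at most a small shift. Compound 3 is therefore expected to come out near compound 2, with a 1.4-fold lower number from compound 2 to compound 3 (0.13 log units; within the scatter) as the estimated step. The estimate for compound 3 is 8000 nM, expected to fall between 3000 nM and 22000 nM.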

Compound 3, concentration for 50% growth inhibition: 15100 nM
Beside the measured number, compound 3's estimate is 1.9-fold (0.28 log units) below it, within the range that was stated.
By their numbers in this assay, from the lowest: compounds 1, 2 and 3 (each within the scatter of the next, the first and the last beyond it).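

In this assay, fluoro in place of hydrogen on an aromatic carbon, ortho to a large group, gives a 1.4-fold higher number from compound 2 to compound 3 (0.15 log units; within the scatter), so on this pair the (2-fluorobenzyl)oxy group cannot be told apart from the benzyloxy group. For the compounds shown here, with the (2-fluorobenzyl)oxy group the same in both compounds, chloro in place of methoxy on an aromatic carbon gives a 2.5-fold higher number from compound 1 to compound 3 (0.40 log units; beyond the scatter), a modest step that lies beyond the scatter, so here the single change that can be told apart is this one and not the fluoro change. Nothing available explains either step.

Still open is whether the fluoro step would stay this small in a compound carrying methoxy rather than chloro, since the pair shown covers only the chloro series. From the compounds shown here alone, it is also open whether a group unlike fluoro at the same place, such as an amine or a carboxylic acid, would shift the number in this assay by more than the scatter, in either direction.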